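Compound 4: 4-methylphenyl in place of 4-chlorophenyl

The source may report more compounds than this note shows. Statements on the series, on what has been measured and on what is new or still open speak of the compounds shown alone.

In a functional assay on HL-60 cells (Homo sapiens) for inhibition, read by CCK-8 assay, with a stated time of 48 h, tested at 20 uM (a higher number here means more inhibition of growth at the concentration tested, a lower number less inhibition of growth), compound 1 `COc1ccc(S(=O)(=O)Oc2ccccc2/C=C(\C#N)C(=O)Nc2nnc(Cc3cccc4ccccc34)s2)cc1` gives 98%, compound 2 `COc1ccc(S(=O)(=O)Oc2ccccc2/C=C(\C#N)C(=O)Nc2nnc(Cc3cccc(F)c3)s2)cc1` gives 100% and compound 3 `COc1ccc(S(=O)(=O)Oc2ccccc2/C=C(\C#N)C(=O)Nc2nnc(Cc3ccc(Cl)cc3)s2)cc1` gives 99%. Compound 3 therefore stands level with both other compounds, within the scatter of each.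

Compound 4 `COc1ccc(S(=O)(=O)Oc2ccccc2/C=C(\C#N)C(=O)Nc2nnc(Cc3ccc(C)cc3)s2)cc1` carries methyl in place of chloro on an aromatic carbon, para to a large group (methyl in place of chloro on an aromatic carbon). For the measured compounds named here, no measured step makes this exact exchange. The nearest evidence comes from exchanges of the whole group on the saturated chain carbon: a number 1 percentage points higher from compound 1 to compound 3 (within the scatter), a number 1 percentage points lower from compound 2 to compound 3 (within the scatter) and a number 2 percentage points higher from compound 1 to compound 2 (within the scatter). All three steps lie within the scatter, and none of the three compounds goes against this picture. No step beyond the scatter is therefore expected in this assay, though the evidence covers only these compounds. The estimated step is a number 3 percentage points lower from compound 3 to compound 4 (within the scatter). Compound 4 is expected at 96%, with an estimated range of 85% to 100%.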

Compound 4, percent growth inhibition at one concentration: 100%
Compound 4: middle estimate off by 4 percentage points, on the low side; low and high end bracket the measured number.
By their numbers in this assay, from the lowest: compounds 1, 3, 2 and 4 (each within the scatter of the next).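

In this assay, for the compounds shown here, the exchange of chloro for methyl on the aromatic carbon gives a number 1 percentage points higher from compound 3 to compound 4 (within the scatter) and is the first reading of a change at this atom alone, with no step beyond the scatter. The exchanges of the whole group read alike, with no change at the digits printed from compound 2 to compound 4 (within the scatter) and a number 2 percentage points higher from compound 1 to compound 4 (within the scatter), so 4-methylphenyl stands level with 3-fluorophenyl, 4-chlorophenyl and naphthalen-1-yl on the saturated chain carbon. Nothing measured here gives a reason for this lack of separation.

All four compounds lie close to complete inhibition at a single concentration, so any differences among them at lower concentrations remain unresolved. On these data alone, whether an amine or a carboxylic acid in place of the methyl, or a longer chain in place of the 4-methylbenzyl, would shift the number also remains open.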